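The source may report more compounds than this note shows. Statements on the series, on what has been measured and on what is new or still open speak of the compounds shown alone.

In a functional assay on MV4-11 cells (Homo sapiens) for antiproliferative activity, read by CellTiter-Glo, with a stated time of 72 h (on this read-out lower numbers stand for stronger inhibition of growth and higher numbers for weaker inhibition of growth), compound 1 `N[C@H]1CC[C@H](Nc2cc(-c3csc(NCC4CCOCC4)n3)c(Cl)cn2)CC1` gives 140 nM, compound 2 `CC(=O)N[C@H]1CC[C@H](Nc2cc(-c3csc(NCC4CCOCC4)n3)c(Cl)cn2)CC1` gives 3600 nM and compound 3 `COCCN[C@H]1CC[C@H](Nc2cc(-c3csc(NCC4CCOCC4)n3)c(Cl)cn2)CC1` gives 170 nM. Two steps fix where compound 3 stands: a 1.2-fold higher number from compound 1 to compound 3 (0.08 log units; within the scatter), and a 21-fold lower number from compound 2 to compound 3 (1.33 log units; beyond the scatter). Compound 4 `COCCCN[C@H]1CC[C@H](Nc2cc(-c3csc(NCC4CCOCC4)n3)c(Cl)cn2)CC1` differs from it by methoxymethyl in place of methoxy on a saturated chain carbon, two bonds along the chain from an amine nitrogen, that is, 2-methoxyethyl becomes 3-methoxypropyl. Among the compounds with values here, no measured step extends this chain. Within the data shown here, the nearest precedent is the 2-methoxyethyl step from hydrogen, which stayed within the scatter, while the large change, a 26-fold higher number from compound 1 to compound 2 (1.41 log units; beyond the scatter), came with acetyl, which compound 4 does not carry. No shift beyond the scatter is therefore expected in this assay, and the estimate is a 1.1-fold higher number from compound 3 to compound 4 (0.02 log units; within the scatter). For compound 4 the expected value is 180 nM, with an estimated range of 80 nM to 420 nM.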

Compound 4, concentration for 50% growth inhibition: 1090 nM
Compound 4: middle estimate off by 6.1-fold (0.78 log units), on the low side; the measured number lies above the stated range.
By their numbers in this assay, from the lowest: compounds 1 and 3 (each within the scatter of the next); then compound 4; then compound 2.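

In this assay, the tolerance seen for 2-methoxyethyl on this amine nitrogen does not extend to 3-methoxypropyl: the change from methoxy to methoxymethyl gives a 6.4-fold higher number from compound 3 to compound 4 (0.81 log units; beyond the scatter), and replacing hydrogen with 3-methoxypropyl gives a 7.8-fold higher number from compound 1 to compound 4 (0.89 log units; beyond the scatter). The number still stays short of the acetyl amide, with a 3.3-fold lower number from compound 2 to compound 4 (0.52 log units; beyond the scatter). Nothing at hand bears on why this chain change shifts growth inhibition. Open, going by these compounds, is whether a longer chain raises the number further, and whether a plain propyl group or a terminal hydroxyl on the same chain behaves like 3-methoxypropyl.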